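The source may hold more compounds than are shown below. What is called first, only, known or untested is meant among the compounds shown, and "the series" means these compounds.

Compound 1 `CCCCCOC(=O)N1CCN(C(=O)c2nc(Nc3cc(C4CC4)[nH]n3)c3cc(Cl)ccc3n2)C[C@H]1C` gives 32.7% in an assay for inhibition of serine/threonine-protein kinase PAK 4 (Homo sapiens), read by FRET and Z'-LYTE, with a stated time of 60 min, tested at 50 uM, in the presence of a further agent that is not named here; on this read-out lower numbers stand for a weaker effect and higher numbers for a stronger effect at the one concentration tested.
Compound 2 `C[C@@H]1CN(C(=O)c2nc(Nc3cc(C4CC4)[nH]n3)c3cc(Cl)ccc3n2)CCN1C(=O)OCOC(=O)C(C)(C)C` gives 60.5%.

Among these two numbers compound 1 stands lowest, with compound 2 above it by a number 27.8 percentage points higher from compound 1 to compound 2 (beyond the scatter). Compound 3 `CC(C)C(=O)OCOC(=O)N1CCN(C(=O)c2nc(Nc3cc(C4CC4)[nH]n3)c3cc(Cl)ccc3n2)C[C@H]1C` is not yet measured; it differs from compound 1 by (isopropylcarbonyl)oxy in place of butyl on a saturated chain carbon bound to an oxygen next to a carbonyl group. Among the measured compounds shown here, the one step that bears on this is the change from compound 1 to compound 2, where ((tert-butyl)carbonyl)oxy entered at the same place, and it was a number 27.8 percentage points higher from compound 1 to compound 2 (beyond the scatter). A rise of similar kind is therefore expected, perhaps somewhat smaller, giving an estimated a number 22.3 percentage points higher from compound 1 to compound 3 (beyond the scatter). Compound 3 is thus expected to reach about 55%, within a range of 35% to 75%.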

Compound 3, a percentage reported as inhibition, at one concentration (the size of the read-out at that concentration, not a potency) in the serine/threonine-protein kinase PAK 4 assay: 86.9%
For compound 3 the middle estimate is 31.9 percentage points below the measured one, and the stated range ends below it.
By their numbers in the serine/threonine-protein kinase PAK 4 assay, from the lowest: compound 1; then compound 2; then compound 3.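

In the serine/threonine-protein kinase PAK 4 assay, the change from the pentyl carbamate to the (isopropylcarbonyl)oxy group gives a number 54.2 percentage points higher from compound 1 to compound 3 (beyond the scatter), while hydrogen in place of one methyl on the ester end gives a number 26.4 percentage points higher from compound 2 to compound 3 (beyond the scatter), so a single methyl at this position clearly alters the read-out. In a physicochemical assay, read by HPLC, in phosphate buffer, with a stated time of 2 h, at pH 7.4 (a higher number here means that more of the compound is left, a lower number that less of the compound is left), compound 1 gives 99.8% and compound 3 gives 93.5%, which lie within the scatter of each other. Nothing available here explains the gain.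

From the compounds shown here alone, whether an acetyloxy group, with a shorter ester end, or a chain ending in an amine would keep this gain remains open.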